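Swapping the aryl group on the ring nitrogen: compound 4

A few compounds are considered here, and "the series" means these few. Any claim that something is new, unique, unknown or untested is made for them only; others in the source may bear on it.

Measured compounds:
compound 1 `COc1ccc(-c2nc(-c3ccccc3)c(-c3ccc4c(c3)NC(=O)CO4)[nH]2)cc1`: 101%
compound 2 `COc1ccc(-n2cc(-c3ccccc3)c(-c3ccc4c(c3)NC(=O)CO4)n2)cc1`: 95.6%
compound 3 `Cc1ccccc1-n1cc(-c2ccccc2)c(-c2ccc3c(c2)NC(=O)CO3)n1`: 94.8%

In a functional assay on A549 cells (Homo sapiens) for cytotoxicity, read by colorimetric assay and MTT assay, with a stated time of 3 days, tested at 1 uM (on this read-out lower numbers stand for a stronger effect and higher numbers for a weaker effect at the one concentration tested), compound 3 gives 94.8%, the lowest of the three numbers, yet within the scatter of both compound 2 and compound 1. Compound 4 `O=C1COc2ccc(-c3nn(-c4ccc(Br)cc4)cc3-c3ccccc3)cc2N1` differs from compound 3 in one place: 4-bromophenyl in place of 2-methylphenyl on an aromatic nitrogen. Among the measured compounds shown here, the one measured step that also exchanges a group on an aromatic nitrogen is a number 0.8 percentage points lower from compound 2 to compound 3 (within the scatter), which stayed within the scatter. The change leading to compound 4 is of the same kind, so no step beyond the scatter is expected in this assay. Compound 4 is therefore estimated to give 95%, with a range from 85% to 105%. The step this estimate means, a number 0.2 percentage points higher from compound 3 to compound 4 (within the scatter), is expected to remain within the scatter.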

Compound 4, a percentage reported as activity, at one concentration (the size of the read-out at that concentration, not a potency): 81.5%
Compound 4: middle estimate off by 13.5 percentage points, on the high side; measured number outside the range, below it.
By their numbers in this assay, from the lowest: compound 4; then compounds 3, 2 and 1 (each within the scatter of the next).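

In this assay, among the compounds shown here, the group on the aromatic nitrogen now makes a difference: 4-bromophenyl in place of 2-methylphenyl gives a number 13.3 percentage points lower from compound 3 to compound 4 (beyond the scatter) and is the first change to pass the scatter. Bromo in place of methoxy on an aromatic carbon gives a number 14.1 percentage points lower from compound 2 to compound 4 (beyond the scatter) as well, so what counts is which group the phenyl ring carries, not just having one there. Nothing measured here explains this result. Still open, going by these compounds, is whether chloro, nitrile or an amine in place of bromo would give a similar step.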